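Trimming the chlorophenyl to methyl: expected cell tolerance

The source may hold more compounds than are shown below. What is called first, only, known or untested is meant among the compounds shown, and "the series" means these compounds.

Of the compounds shown here, three have been measured in an ADME assay on RD cells (Homo sapiens) for cytotoxicity, read by MTT assay, with a stated time of 3 days; a lower number here means that less compound is tolerated, a higher number that more compound is tolerated. Compound 1 `Clc1ccc([C@@H](CCn2cncn2)Cc2ccccc2)cc1` gives 24.4 ug/mL, and compound 2 `Clc1ccc([C@H](CCn2cncn2)Cc2ccccc2)cc1` gives 21.7 ug/mL; the step of a 1.1-fold lower number from compound 1 to compound 2 (0.05 log units; within the scatter) rests on (the fact that compounds 1 and 2 differ only in the configuration as drawn). Compound 3 `Clc1ccc([C@H](CCn2cncn2)Cc2ccccc2)c(Cl)c1` gives 1.9 ug/mL, so the step of an 11-fold lower number from compound 2 to compound 3 (1.06 log units; beyond the scatter) is the only large one seen. Compound 2 thus stands second highest of the three numbers, close to compound 1 and far from compound 3.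

Compound 4 `C[C@H](CCn1cncn1)Cc1ccccc1` has not yet been measured in this assay. It differs from compound 2 by methyl in place of 4-chlorophenyl on a saturated chain carbon bound to two saturated chain carbons, which removes the aryl group and its chlorine altogether. Among the compounds with values here, the one large step, from compound 2 to compound 3, shows that adding a chlorine on the aromatic ring lowers the tolerated concentration sharply; removing the chlorophenyl is the reverse kind of change, so the expected direction for compound 4 is a higher number, by a step of moderate size. Compound 4 is therefore estimated at 60 ug/mL, within 25 ug/mL to 150 ug/mL, an expected step of a 2.8-fold higher number from compound 2 to compound 4 (0.44 log units; beyond the scatter).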

Compound 4, half-maximal cytotoxic concentration: 153 ug/mL
Compound 4: the middle estimate sits 2.6-fold (0.41 log units) below what was measured; the whole stated range lies below it.
By their numbers in this assay, from the lowest: compound 3; then compounds 2 and 1 (each within the scatter of the next); then compound 4.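

In this assay, the group itself on the saturated chain carbon bound to two saturated chain carbons proves to matter: methyl in place of 4-chlorophenyl gives a 7.1-fold higher number from compound 2 to compound 4 (0.85 log units; beyond the scatter), a step beyond the scatter at a carbon where the earlier compounds had shown only a change of drawn configuration, which stayed within it. The 4-chlorophenyl is therefore not needed for a compound of this series to be measurable here, and cells tolerate more of the compound once it is replaced by methyl. Nothing available here accounts for the size of this step.

Since the ring and its chlorine leave together, the step does not separate their shares. On these data alone, how an unsubstituted phenyl, an amine or a longer chain would stand at this place remains open, as does the other drawn configuration of compound 4.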